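A few compounds are considered here, and "the series" means these few. Any claim that something is new, unique, unknown or untested is made for them only; others in the source may bear on it.

Of the compounds shown here, three sharing one core have been measured in a functional assay on SMMC-7721 cells (Homo sapiens) for cytotoxicity, read by MTT assay, with a stated time of 72 h; a lower number here means a stronger inhibitor, a higher number a weaker inhibitor. Compound 1 `COc1ccc(COCNc2n[n+]([O-])c3ccccc3[n+]2[O-])cc1` gives 1150 nM. Compound 2 `[O-][n+]1nc(NCOCc2ccccc2)[n+]([O-])c2ccccc21` gives 4790 nM, and compound 3 `CCCCCOCNc1n[n+]([O-])c2ccccc2[n+]1[O-]` gives 3050 nM.

The not yet measured compound 4 `CCCCCOCNc1n[n+]([O-])c2cc(OC)ccc2[n+]1[O-]` is reached from compound 3 by methoxy in place of hydrogen on an aromatic carbon. A change of the same kind has already been seen once, from compound 2 to compound 1, where methoxy in place of hydrogen on an aromatic carbon brought a 4.2-fold lower number from compound 2 to compound 1 (0.62 log units; beyond the scatter). The two cases are the same kind of change, not the same: in compound 1 the methoxy stands para to a large group on a ring that is not fused, while in compound 4 it stands on a ring that is part of a fused or bridged system of two rings, meta to a fused ring and para to a fused ring. The cores of the two starting points also differ, by butyl in place of phenyl on a saturated chain carbon bound to an oxygen on a saturated carbon, which gave a 1.6-fold lower number from compound 2 to compound 3 (0.20 log units; within the scatter).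

Resting on the step seen from compound 2 to compound 1, compound 4 is expected to show a 3.1-fold lower number from compound 3 to compound 4 (0.48 log units; beyond the scatter) in this assay, with room left for a smaller gain. Going by the values given here, the place of the change is not the same in the two cases, and no measured step tells how much that matters. The estimate for compound 4 is 1000 nM.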

Compound 4, half-maximal inhibitory concentration: 550 nM
Compound 4: the middle estimate sits 1.8-fold (0.26 log units) above what was measured; the range from low to high includes it.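

In this assay, methoxy in place of hydrogen on an aromatic carbon gives a 5.5-fold lower number from compound 3 to compound 4 (0.74 log units; beyond the scatter), and this step agrees with the one seen earlier on a different core: the same change on two cores in this assay, a 4.2-fold lower number (0.62 log units; beyond the scatter) from compound 2 to compound 1 and a 5.5-fold lower number (0.74 log units; beyond the scatter) from compound 3 to compound 4, 1.3-fold (0.12 log units) apart, within the scatter of two such steps. Within these four compounds, then, the change carries from one core to the other with about the same size, even though the methoxy stands on a ring that is not fused in compound 1 and on a ring that is part of a fused system in compound 4. Still, two pairs in a single assay do not make a general rule, and they do not show why the number falls or whether the same would hold on other cores in the series.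

Going by these compounds, it remains open whether an amine or a longer ether chain such as ethoxy, placed where compound 4 carries its methoxy, would lower the number as well. Also open, on these data alone, is whether the methoxy of compound 1 and that of compound 4, brought together in one molecule, would add up.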